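The compounds below may be only part of what the source reports. "The series", "measured", "known", "first", "only" and "open" are said of these compounds alone.

Measured values in a functional assay on MCF7 cells (Homo sapiens) for inhibition, read by MTT assay, with a stated time of 72 h (a higher number here means a weaker inhibitor, a lower number a stronger inhibitor), follow
compound 1 `COc1cc(OC)c(OC)cc1/C=C/C(=O)c1ccc(-c2c[nH]cn2)cc1` gives > 150000 nM
compound 2 `COc1cc(OC)c(OC)cc1/C=C/C(=O)c1cc(Cl)ccc1O` gives > 150000 nM

Compound 2 gives only a limit of the assay (> 150000 nM), not a number. Both entries share it (the limit of > 150000 nM in this assay, at which 2 of the 2 values shown sit). Compound 3 `COc1cc(OC)c(OC)cc1/C=C/C(=O)c1ccc(F)cc1` has 4-fluorophenyl in place of 5-chloro-2-hydroxyphenyl on a carbonyl carbon. In this assay no measured step sizes this change. A small move toward stronger inhibition is expected, possibly none beyond the scatter, and another limit would be no surprise. The expected step (an at least 1.5-fold lower number from compound 2 to compound 3 (0.17 log units; that floor lies within the scatter)) is therefore a rough one. Compound 3 is estimated at 100000 nM with 30000 nM to 200000 nM as the expected range.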

Compound 3, half-maximal inhibitory concentration: 30000 nM
Estimate against measurement, compound 3: 3.3-fold (0.52 log units) above, within the range that was stated.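

In this assay, the aryl group on the carbonyl carbon now shows a readable effect: 4-fluorophenyl in place of 5-chloro-2-hydroxyphenyl brings an at least 5.0-fold lower number from compound 2 to compound 3 (0.69 log units; beyond the scatter). On the aromatic carbon, fluoro in place of 1H-imidazol-4-yl brings an at least 5.0-fold lower number from compound 1 to compound 3 (0.69 log units; beyond the scatter). Both steps are only minimum sizes because each starts from a limit of the assay: the limit of > 150000 nM in this assay, at which 2 of the 3 values shown sit.

The compounds shown do not separate the loss of the chloro from the loss of the hydroxy in compound 2. From the compounds shown here alone, how an amine or a carboxylic acid in place of the fluoro of compound 3 would read remains open.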